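From 3-methoxyazetidin-1-yl to dimethylamino on the carbonyl

The source may report more compounds than this note shows. Statements on the series, on what has been measured and on what is new or still open speak of the compounds shown alone.

In an ADME assay (liver) for metabolic stability, with Liver microsome (Homo sapiens) as the target, using microsomes (a lower number here means slower removal, a higher number faster removal of the compound), compound 1 `Cc1cnc(NC(=O)c2cc(Oc3ccc(C#N)cc3)c3cc(C)oc3c2)cn1` gives 29 mL/min/kg and compound 2 `CNC(=O)c1cnc(Oc2cc(C(=O)Nc3cnc(C)cn3)cc3oc(C)cc23)cn1` gives 10.1 mL/min/kg as its number. In this assay compound 3 `COC1CN(C(=O)c2cnc(Oc3cc(C(=O)Nc4cnccn4)cc4oc(C)cc34)cn2)C1` reports < 9.2 mL/min/kg as a limit and not a number. Compound 4 `Cc1cc2c(Oc3cnc(C(=O)N(C)C)cn3)cc(C(=O)Nc3cnccn3)cc2o1` carries dimethylamino in place of 3-methoxyazetidin-1-yl on a carbonyl carbon. Going by the values given here, the only measured step, a 2.9-fold lower number from compound 1 to compound 2 (0.46 log units; beyond the scatter) with 5-(methylcarbamoyl)pyrazin-2-yl in place of 4-cyanophenyl, is a different exchange and sets no size for this one. The expected step (an at least 1.0-fold higher number from compound 3 to compound 4 (0.03 log units; that floor lies within the scatter)) is therefore none beyond the scatter in this assay and has no firm direction. Compound 4 is estimated at 10 mL/min/kg in this assay (expected range 6.5 mL/min/kg to 18 mL/min/kg).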

Compound 4, clearance: 15 mL/min/kg
Estimate against measurement, compound 4: 1.5-fold (0.18 log units) below; measured number inside the range.
By their numbers in this assay, from the lowest: compounds 2, 4 and 1 (each within the scatter of the next, the first and the last beyond it). At a limit, below all of these: compound 3.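

In this assay, the carbonyl carbon now has a direct exchange of one amide group for another, and dimethylamino in place of 3-methoxyazetidin-1-yl gives an at least 1.6-fold higher number from compound 3 to compound 4 (0.21 log units; that floor lies within the scatter). The direction of this change therefore remains unsettled. Compound 3 reports < 9.2 mL/min/kg, a limit and not a number, so only a floor of the step can be read: the limit of < 9.2 mL/min/kg in this assay, at which 1 of the 4 values shown sits.

The compounds shown leave open whether the ring or its methoxy group matters here, a split that unsubstituted azetidin-1-yl on the same carbonyl would address. Going by these compounds, how a larger ring amine, such as morpholine, would read on this carbonyl also remains open.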